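Dopamine transporter binding: cyclopropyl to tert-butyl on the piperidine amine

The source may hold more compounds than are shown below. What is called first, only, known or untested is meant among the compounds shown, and "the series" means these compounds.

Measured so far:
compound 1 `Fc1ccc(C(SCCNC2CCN(Cc3ccccc3)CC2)c2ccc(F)cc2)cc1` gives 32.9 nM in an assay on membranes from striatum (strain Sprague-Dawley) for displacement of a labelled ligand from sodium-dependent dopamine transporter (Rattus norvegicus), read by scintillation counting, with a stated time of 120 min; a lower number here means a stronger inhibitor, a higher number a weaker inhibitor
compound 2 `Fc1ccc(C(SCCNC2CCN(CC3CC3)CC2)c2ccc(F)cc2)cc1` gives 407 nM in this assay

Compound 2 holds the highest of the two numbers in this assay; its nearest neighbour is compound 1, reached by a 12-fold higher number from compound 1 to compound 2 (1.09 log units; beyond the scatter). Among the compounds with values here, that single step, phenyl exchanged for cyclopropyl on a saturated chain carbon bound to an amine nitrogen in a ring, is the only measured change.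

Compound 3 `CC(C)(C)CN1CCC(NCCSC(c2ccc(F)cc2)c2ccc(F)cc2)CC1` has not been measured. It differs from compound 2 by tert-butyl in place of cyclopropyl on a saturated chain carbon bound to an amine nitrogen in a ring. Within the data shown here, no measured step compares two saturated groups at this place; the one known step, from an aromatic ring to a small saturated ring, was large, but it gives no direct guide for a saturated-to-saturated exchange. An unexpected shift in either direction is therefore possible, and the expectation is a step of a 1.2-fold higher number from compound 2 to compound 3 (0.09 log units; within the scatter), close to none beyond the scatter. Compound 3 is estimated at 500 nM, within 150 nM to 1700 nM.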

Compound 3, inhibition constant: 279 nM
Beside the measured number, compound 3's estimate is 1.8-fold (0.25 log units) above it; measured number inside the range.
By their numbers in this assay, from the lowest: compound 1; then compounds 3 and 2 (each within the scatter of the next).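

In this assay, a 1.5-fold lower number from compound 2 to compound 3 (0.16 log units; within the scatter) stays within the scatter, so at this place, on a saturated chain carbon bound to an amine nitrogen in a ring, the numbers do not separate tert-butyl from cyclopropyl, although only cyclopropyl has a ring. Against phenyl, the tert-butyl exchange gives an 8.5-fold higher number from compound 1 to compound 3 (0.93 log units; beyond the scatter), so the gap first seen with cyclopropyl now appears with a second saturated group, and both compound 2 and compound 3 are weaker than compound 1. No supporting data are at hand to account for this result.

Open, as far as these compounds go, is whether the gap belongs to aromatic rings in general or to phenyl alone, which cyclohexyl, pyridyl or a fluorophenyl at this place would test. Also open, from the compounds shown here alone, is how a longer chain between the ring amine and the phenyl would read.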